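The compounds below may be only part of what the source reports. "The series", "measured", "known", "first", "only" and "open" are said of these compounds alone.

Measured so far:
compound 1 `CCn1c(C(=O)NCCN(C)C)ccc1C(CC)(CC)c1ccc(OCC(=O)C(C)(C)C)c(C)c1`: 77 nM
compound 2 `C#CCNC(=O)c1ccc(C(CC)(CC)c2ccc(OCC(=O)C(C)(C)C)c(C)c2)n1CC`: 2200 nM

In an assay on HL-60 cells for agonist activity at vitamin D3 receptor (Homo sapiens), read by microscopy, with a stated time of 96 h (a higher number here means that more compound is needed for the effect, a lower number that less compound is needed), compound 2 gives 2200 nM, the higher of the two numbers; its nearest neighbour is compound 1, separated by the step of a 29-fold higher number from compound 1 to compound 2 (1.46 log units; beyond the scatter). Compound 3 `CCn1c(C(=O)N(C)CCC#N)ccc1C(CC)(CC)c1ccc(OCC(=O)C(C)(C)C)c(C)c1` differs from compound 2 by (2-cyanoethyl)(methyl)amino in place of propargylamino on a carbonyl carbon. Going by the values given here, only that one measured step touches the group on the carbonyl carbon, and it was large, so this part of the molecule clearly matters, but no measured compound carries the (2-cyanoethyl)(methyl)amino group, so the direction is uncertain. A step of a 3.7-fold lower number from compound 2 to compound 3 (0.56 log units; beyond the scatter) toward a lower number is expected. For compound 3 the estimated value is 600 nM, within 120 nM to 3000 nM.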

Compound 3, half-maximal effective concentration: 9800 nM
Estimate against measurement, compound 3: 16-fold (1.21 log units) below; the whole stated range lies below it.
By their numbers in this assay, from the lowest: compound 1; then compound 2; then compound 3.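

In this assay the steps of a 4.5-fold higher number from compound 2 to compound 3 (0.65 log units; beyond the scatter) and a 130-fold higher number from compound 1 to compound 3 (2.10 log units; beyond the scatter) show that the propargylamino group was not the worst choice on this carbonyl carbon: of the three groups, (2-cyanoethyl)(methyl)amino gives the highest number and (2-(dimethylamino)ethyl)amino the lowest. Compound 3 also has no amide hydrogen, unlike compound 1 and compound 2. No measurement here explains these differences.

Still open, going by these compounds, is whether the nitrile or the lost amide hydrogen matters more; the plain 2-cyanoethylamino group, which keeps that hydrogen, would separate the two.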